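The compounds below may be only part of what the source reports. "The series", "measured", "known", "first", "only" and "open" are said of these compounds alone.

Compound 1 `CCOC(=O)/N=C(/Nc1cccnc1)NC(C)(C)CC` gives 20 mg/kg in a functional assay on the whole organism (blood, strain Wistar-Okamoto) with Rattus norvegicus as the target, with a stated time of 5 days; on this read-out lower numbers stand for an effect already at smaller amounts and higher numbers for an effect only at larger amounts of compound. Compound 2 `CCC(C)(C)N/C(=N\C(=O)C(F)(F)F)Nc1cccnc1` reaches only the assay boundary (the limit of > 50 mg/kg in this assay, at which 1 of the 2 values shown sits), so its value of > 50 mg/kg is a limit rather than a number. Among the compounds with values here, the one measured step, an at least 2.5-fold higher number from compound 1 to compound 2 (0.39 log units; beyond the scatter), ran toward larger amounts. Within the data shown here, compound 3 `CCC(C)(C)N/C(=N\c1cnccn1)Nc1cccnc1` carries pyrazin-2-yl in place of (trifluoromethyl)carbonyl on a double-bonded nitrogen, a change that no measured step covers, so its direction stays open. Compound 3 is estimated to give 30 mg/kg, between 10 mg/kg and 100 mg/kg. The expected step of an at least 1.6-fold lower number from compound 2 to compound 3 (0.22 log units; that floor lies within the scatter) points toward a smaller amount, with wide uncertainty.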

Compound 3, minimum effective dose: 25 mg/kg
Beside the measured number, compound 3's estimate is 1.2-fold (0.08 log units) above it; measured number inside the range.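

On a double-bonded nitrogen, a carbonyl group proves unnecessary for an effect at this level, since the aromatic pyrazin-2-yl group matches ethoxycarbonyl: a 1.3-fold higher number from compound 1 to compound 3 (0.10 log units; within the scatter). As far as these compounds go, replacing (trifluoromethyl)carbonyl with pyrazin-2-yl gives an at least 2.0-fold lower number from compound 2 to compound 3 (0.30 log units; that floor lies within the scatter), and this is only a floor, so the true size of the step stays unknown. Compound 2 has a limit rather than a number: the limit of > 50 mg/kg in this assay, at which 1 of the 3 values shown sits.

The compounds shown leave open whether a nitrile or a phenyl group on this double-bonded nitrogen would give a similar effect in this assay.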